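A few compounds are considered here, and "the series" means these few. Any claim that something is new, unique, unknown or untested is made for them only; others in the source may bear on it.

Compound 2 `O=C1CNC(=O)N1C[C@H]1CN(c2ccc(-n3cc(-c4ccccn4)cn3)c(F)c2)C(=O)O1` has been tested in an ADME assay on HEK293-A cells (Homo sapiens) for cytotoxicity, read by MTT assay, with a stated time of 48 h; on this read-out lower numbers stand for stronger inhibition and higher numbers for weaker inhibition. For compound 2 the read-out is only a limit of the assay, > 400 ug/mL. Within the data shown here, its one measured neighbour is compound 1 `CN(CCC#N)C[C@H]1CN(c2ccc(-n3cc(-c4ccccn4)cn3)c(F)c2)C(=O)O1`, which differs from it in a single place. For compound 1 the read-out is likewise a limit, > 400 ug/mL. Among the measured compounds shown here, the only measured step, a step that the two limits leave unreadable from compound 1 to compound 2, cannot be given a size, since both of its ends sit at the limit of > 400 ug/mL in this assay, at which 2 of the 2 values shown sit. Compound 3 `CS(=O)(=O)NC[C@H]1CN(c2ccc(-n3cc(-c4ccccn4)cn3)c(F)c2)C(=O)O1` has not yet been measured. It differs from compound 2 in one place: methanesulfonamido in place of 2,5-dioxoimidazolidin-1-yl on a saturated chain carbon bound to a saturated ring carbon. For the measured compounds named here, no measured step bears on this particular change, and the single step available shows no size at all. The expectation is that compound 3 again reaches the same limit, so that the step that the limit leaves unreadable from compound 2 to compound 3 is expected to lie within the scatter. Compound 3 is estimated at 450 ug/mL, with a range from 300 ug/mL to 800 ug/mL.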

Compound 3, half-maximal inhibitory concentration: 314 ug/mL
For compound 3 the middle estimate is 1.4-fold (0.16 log units) above the measured one; the measured number falls inside the stated range.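

In this assay, among these compounds, compound 3, with methanesulfonamido on this saturated chain carbon, gives 314 ug/mL, the only one of the three values that is a number and not a limit. The change from the ring group 2,5-dioxoimidazolidin-1-yl gives an at least 1.2-fold lower number from compound 2 to compound 3 (0.10 log units; that floor lies within the scatter), and the change from (2-cyanoethyl)(methyl)amino gives an at least 1.2-fold lower number from compound 1 to compound 3 (0.10 log units; that floor lies within the scatter), so neither step is shown to go beyond the usual scatter. The true size of both steps stays unknown because their other ends rest on a limit: the limit of > 400 ug/mL in this assay, at which 2 of the 3 values shown sit.

The compounds shown leave open whether a number rather than a limit belongs to methanesulfonamido alone. A plain primary amine or an acetamido group on this carbon, or the longer ethanesulfonamido chain, could settle that question.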